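This account rests on a few compounds, and the source may have more. Where it says the series, first, only, none or still open, it means among the compounds named here.

Compound 1 `CC(C)c1n[nH]c2c(NCc3ccc(-c4ccccn4)cc3)nc(SCC(O)CN)nc12` is the reference point of this comparison. Going by the values given here, in a functional assay on HT cells (Homo sapiens) for antiproliferative activity, read by fluorescence, with a stated time of 72 h (on this read-out lower numbers stand for stronger inhibition of growth and higher numbers for weaker inhibition of growth), compound 1 gives 55 nM, the second highest of the three numbers measured so far. Compound 2 `CC(C)c1n[nH]c2c(NCc3ccc(-c4ccccn4)cc3)nc(SCCN)nc12` gives 22 nM and compound 3 `CC(C)c1n[nH]c2c(NCc3ccc(-c4ccccn4)cc3)nc(SCCC(N)=O)nc12` gives 120 nM. The step of a 2.5-fold lower number from compound 1 to compound 2 (0.40 log units; beyond the scatter) and the step of a 2.2-fold higher number from compound 1 to compound 3 (0.34 log units; beyond the scatter) place compound 1 between its two neighbours, and the step of a 5.5-fold higher number from compound 2 to compound 3 (0.74 log units; beyond the scatter) is the largest of the set.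

Compound 4 `CC(C)c1n[nH]c2c(NCc3ccc(-c4ccccn4)cc3)nc(SCCn3ccnc3)nc12` has not yet been measured; relative to compound 1 the change is (1H-imidazol-1-yl)methyl in place of 2-amino-1-hydroxyethyl on a saturated chain carbon bound to a sulfur. Among the compounds with values here, none of the measured steps makes this exact change, but all three alter the same saturated chain carbon bound to a sulfur or the position two bonds along the chain from a sulfur. The step of a 2.2-fold higher number from compound 1 to compound 3 (0.34 log units; beyond the scatter), where 2-amino-1-hydroxyethyl gives way to carbamoylmethyl, and the step of a 5.5-fold higher number from compound 2 to compound 3 (0.74 log units; beyond the scatter), where amino gives way to carbamoyl, both raised the number when the amino group was lost; the step of a 2.5-fold lower number from compound 1 to compound 2 (0.40 log units; beyond the scatter) lowered it when the amino group stayed. Since compound 4 keeps neither the amino nor the hydroxy part of 2-amino-1-hydroxyethyl, a modest rise in the number is expected, a 1.6-fold higher number from compound 1 to compound 4 (0.21 log units; within the scatter). Compound 4 is therefore estimated at 90 nM in this assay, with a range from 30 nM to 270 nM.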

Compound 4, concentration for 50% growth inhibition: 155 nM
Compound 4: middle estimate off by 1.7-fold (0.24 log units), on the low side, and the stated range covers the measured number.
By their numbers in this assay, from the lowest: compound 2; then compound 1; then compounds 3 and 4 (each within the scatter of the next).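

In this assay, placing (1H-imidazol-1-yl)methyl in place of 2-amino-1-hydroxyethyl on a saturated chain carbon bound to a sulfur gives a 2.8-fold higher number from compound 1 to compound 4 (0.45 log units; beyond the scatter) and shows that a five-membered aromatic ring with no hydrogen-bond donors at this position does not match the amino-bearing chains. The step of a 1.3-fold higher number from compound 3 to compound 4 (0.11 log units; within the scatter) lies within the scatter, so the 1H-imidazol-1-yl and carbamoyl ends cannot be told apart here despite their different groups. The step of a 7.0-fold higher number from compound 2 to compound 4 (0.85 log units; beyond the scatter) is the widest in the set, and among these four compounds, with no exception, the two that carry an amino group, compounds 1 and 2, both have lower numbers than compounds 3 and 4, which carry none.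

Nothing available bears on the reason for these differences. Still open, going by these compounds, is whether a dimethylamino group, a carboxylic acid or a longer chain ending in an amino group would stand with compound 2 or with compounds 3 and 4, and whether a ring that also carries an amino group would restore the lower numbers.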